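Swapping Heptylamino for Heptylsulfanyl on a Shared Core

The compounds below may be only part of what the source reports. "The series", "measured", "known", "first", "only" and "open" are said of these compounds alone.

In an assay on microsomes from liver for inhibition of sterol O-acyltransferase 1 (Rattus norvegicus) (on this read-out higher numbers stand for weaker inhibition and lower numbers for stronger inhibition), the measured compounds stand as follows:
compound 1 `O=C(O)CCCCCCn1nc(-c2ccccc2)c(-c2ccccc2)cc1=O`, a limit of the assay rather than a number: > 300000 nM
compound 2 `CCCCCCCNc1cc(-c2ccccc2)c(-c2ccccc2)nn1`: 55000 nM
compound 3 `CCCCCCCCCOc1cc(-c2ccccc2)c(-c2ccccc2)nn1`: 180000 nM

Compound 2 holds the lowest of the two numbers; compound 3 sits higher, beyond the scatter. Compound 4 `CCCCCCCSc1cc(-c2ccccc2)c(-c2ccccc2)nn1` differs from compound 2 by heptylsulfanyl in place of heptylamino on an aromatic carbon. Going by the values given here, no pair of measured compounds shows this exact change. The nearest hint is compound 3, where an alkoxy chain replaces the amino group and the number rises. The expected step is a moderate weakening, a 2.0-fold higher number from compound 2 to compound 4 (0.30 log units; within the scatter), though the move could also be within the scatter. Compound 4 is therefore estimated at 110000 nM, with a range from 35000 nM to 300000 nM.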

Compound 4, half-maximal inhibitory concentration: 76000 nM
Estimate against measurement, compound 4: 1.4-fold (0.16 log units) above, within the range that was stated.
By their numbers in this assay, from the lowest: compounds 2 and 4 (each within the scatter of the next); then compound 3. At a limit, above all of these: compound 1.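

At this aromatic carbon, heptylsulfanyl in place of heptylamino gives a 1.4-fold higher number from compound 2 to compound 4 (0.14 log units; within the scatter) in this assay, so the two compounds cannot be told apart here. The hydrogen-bond donor of heptylamino can therefore go without a change this read-out can resolve, which compound 3, with its different chain length, could not show. Nothing measured here bears on the cause of this result. Still open, from the compounds shown here alone, is whether a heptyloxy chain would match these two compounds. Also open, going by these compounds, is whether a longer chain on the sulfur, or an amine at the chain's end, would move the number beyond the scatter.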